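Replacing the Phenyl on the Amide Chain of Compound 3

The source may report more compounds than this note shows. Statements on the series, on what has been measured and on what is new or still open speak of the compounds shown alone.

Compound 1 `CCCn1c(SCc2cc([N+](=O)[O-])ccc2OC)nc2cc(NC(=O)NC(C)(C)C)cc(C(=O)OC)c21` in an assay on isolated protein for inhibition of Gonadotropin-releasing hormone receptor (Homo sapiens); on this read-out higher numbers stand for weaker inhibition and lower numbers for stronger inhibition: 37 nM
Compound 2 `CCCn1c(SCc2cc([N+](=O)[O-])ccc2OC)nc2cc(NC(=O)NC(C)(C)C)cc(C(=O)NC)c21` in this assay: 41 nM
Compound 3 `CCCn1c(SCc2cc([N+](=O)[O-])ccc2OC)nc2cc(NC(=O)NC(C)(C)C)cc(C(=O)NCc3ccccc3)c21` in this assay: 120 nM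

Compound 3 has the highest number of the three measured compounds; compound 2 lies nearest, as a 2.9-fold higher number from compound 2 to compound 3 (0.47 log units; beyond the scatter) shows, and compound 1 furthest, as a 3.2-fold higher number from compound 1 to compound 3 (0.51 log units; beyond the scatter) shows. Compound 4 `CCCn1c(SCc2cc([N+](=O)[O-])ccc2OC)nc2cc(NC(=O)NC(C)(C)C)cc(C(=O)NCCCN(C)C)c21` differs from compound 3 in one place: 2-(dimethylamino)ethyl in place of phenyl on a saturated chain carbon bound to an amide-type nitrogen. The step that bears on this is the one that brought the phenyl in, a 2.9-fold higher number from compound 2 to compound 3 (0.47 log units; beyond the scatter), a modest rise; the ester-to-amide step a 1.1-fold higher number from compound 1 to compound 2 (0.04 log units; within the scatter) stayed within the scatter. Taking the phenyl away could give back part of that rise, but nothing measured here shows what the entering chain does. A modest move to a lower number is therefore expected, a 2.0-fold lower number from compound 3 to compound 4 (0.30 log units; within the scatter), with wide uncertainty. Compound 4 is estimated at 60 nM, between 25 nM and 150 nM.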

Compound 4, half-maximal inhibitory concentration: 170 nM
The estimate for compound 4 lay 2.8-fold (0.45 log units) below the measured number; the measured number lies above the stated range.
By their numbers in this assay, from the lowest: compounds 1 and 2 (each within the scatter of the next); then compounds 3 and 4 (each within the scatter of the next).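

In this assay the phenyl can give way to a ring-free chain ending in a dimethylamino group with no change beyond the scatter (a 1.4-fold higher number from compound 3 to compound 4 (0.15 log units; within the scatter)), so a ring on this chain is not what sets the reading. The new chain still leaves a modest gap to the small groups on the carbonyl carbon (a 4.1-fold higher number from compound 2 to compound 4 (0.62 log units; beyond the scatter)) and (a 4.6-fold higher number from compound 1 to compound 4 (0.66 log units; beyond the scatter)), as benzylamino did. No evidence here explains these readings.

A plain propyl chain would show whether the amine matters. From the compounds shown here alone, a chain ending in a carboxylic acid, or a shorter chain ending in the same amine, remains open too.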